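A few compounds are considered here, and "the series" means these few. Any claim that something is new, unique, unknown or untested is made for them only; others in the source may bear on it.

Of the compounds shown here, three of a shared core have been tested in a functional assay on HeLa cells (Homo sapiens) for cytotoxicity, read by neutral red uptake, with a stated time of 3 days (a lower number here means a stronger inhibitor, a higher number a weaker inhibitor), so far, and a fourth awaits its turn. Compound 1 `Nc1ccc(-c2cc(=O)c3c(N)c(F)c(O)c(F)c3o2)cc1F` reaches only a limit of the assay, reported as > 100000 nM rather than as a number. Compound 2 `Nc1ccc(-c2cc(=O)c3c(N)c(F)c(N)c(F)c3o2)cc1F` gives a number, 19000 nM. The step of an at least 5.2-fold lower number from compound 1 to compound 2 (0.72 log units; beyond the scatter) is the one clear movement among these three. Compound 3 `CCOC(=O)c1c(F)c(N)c2c(=O)cc(-c3ccc(N)c(F)c3)oc2c1F` again sits at a limit, > 100000 nM, so its standing is known only as a boundary. This is reflected in the limit of > 100000 nM in this assay, at which 2 of the 3 values shown sit, which puts two of the three values at the same ceiling. The step that the two limits leave unreadable from compound 1 to compound 3 cannot be sized for that reason, while the step of an at least 5.2-fold higher number from compound 2 to compound 3 (0.72 log units; beyond the scatter) is readable and points upward.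

Compound 4 `CCCCCC(=O)OCc1c(F)c(N)c2c(=O)cc(-c3ccc(N)c(F)c3)oc2c1F` differs from compound 3 in one place: ((pentylcarbonyl)oxy)methyl in place of ethoxycarbonyl on an aromatic carbon. Among the compounds with values here, no measured step swaps one of these two groups for the other, so the closest guide is compound 3 itself, whose value > 100000 nM is a limit. The expectation is therefore a step of about a number no higher from compound 3 to compound 4 (the limit leaves the size open), that is, no movement beyond the scatter, with compound 4 most likely also ending at the ceiling. The estimate for compound 4 is 100000 nM, within a range from 30000 nM to 300000 nM.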

Compound 4, half-maximal inhibitory concentration: 34000 nM
Beside the measured number, compound 4's estimate is 2.9-fold (0.47 log units) above it, and the stated range covers the measured number.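

The swap at this position, the aromatic carbon ortho to two fluoro groups, gives an at least 2.9-fold lower number from compound 3 to compound 4 (0.46 log units; beyond the scatter), so in this assay an ester-bearing group here need not leave the compound at the ceiling. Set against the other groups at this place, ((pentylcarbonyl)oxy)methyl gives an at least 2.9-fold lower number from compound 1 to compound 4 (0.46 log units; beyond the scatter) relative to hydroxy, and a 1.8-fold higher number from compound 2 to compound 4 (0.25 log units; within the scatter) relative to amino, so those last two compounds stand level. Amino is therefore no longer the only group at this position that yields a readable number, while two compounds still give only a limit: the limit of > 100000 nM in this assay, at which 2 of the 4 values shown sit.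

The change from ethoxycarbonyl to ((pentylcarbonyl)oxy)methyl alters both the length of the chain and the way the ester is joined to the ring, and the compounds shown do not separate these two differences. A hydroxymethyl group, a carboxylic acid or an acetoxymethyl group with its shorter chain at this position would show whether the ester, the chain or the link to the ring goes with the readable number.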